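A Side-Chain Swap from Compound 3 to Compound 4

The source may report more compounds than this note shows. Statements on the series, on what has been measured and on what is new or still open speak of the compounds shown alone.

Values measured in a functional assay on MDA-MB-231 cells (Homo sapiens) for inhibition, read by MTT assay, with a stated time of 24 h; a higher number here means a weaker inhibitor of growth, a lower number a stronger inhibitor of growth:
- Compound 1 `N[C@@H](CCC(=O)OC[C@H]1O[C@@H](n2cc(F)c(=O)[nH]c2=O)C[C@@H]1OC(=O)CC[C@H](N)C(=O)O)C(=O)O`: 37300000 nM
- Compound 2 `N[C@@H](CC(=O)OC[C@H]1O[C@@H](n2cc(F)c(=O)[nH]c2=O)C[C@@H]1OC(=O)C[C@H](N)C(=O)O)C(=O)O`: 33100000 nM
- Compound 3 `N[C@@H](CCC(=O)O[C@H]1C[C@H](n2cc(F)c(=O)[nH]c2=O)O[C@@H]1CO)C(=O)O`: 34900000 nM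

The three values lie within the scatter of one another, so compound 3 stands level with both of the others and no ranking can be drawn among them.

Compound 4 `CC(C)[C@H](N)C(=O)O[C@H]1C[C@H](n2cc(F)c(=O)[nH]c2=O)O[C@@H]1CO` keeps the core of compound 3 but carries 1-amino-2-methylpropyl in place of 3-amino-3-carboxypropyl on a carbonyl carbon. For the measured compounds named here, no measured compound yet carries the incoming group, so the data contain no direct test of this change.

Going by the values given here, only one measured step bears on it, and only indirectly: a 1.1-fold lower number from compound 1 to compound 3 (0.03 log units; within the scatter). That step removes one of the two acyl chains of compound 1 and leaves the number within the scatter. Compound 2, with shorter chains, gives 33100000 nM, which is also within the scatter of the other two values. The numbers have therefore stayed flat across every variation tested so far, and no step beyond the scatter is expected here, in either direction.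

The expected step is a 1.2-fold lower number from compound 3 to compound 4 (0.07 log units; within the scatter), and this is only an estimate. In this assay, the estimated value for compound 4 is 30000000 nM, with an expected range from 12000000 nM to 60000000 nM.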

Compound 4, concentration for 50% growth inhibition: 32400000 nM
Estimate against measurement, compound 4: 1.1-fold (0.03 log units) below; the measured number falls inside the stated range.
By their numbers in this assay, from the lowest: compounds 4, 2, 3 and 1 (each within the scatter of the next).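

Putting 1-amino-2-methylpropyl in place of 3-amino-3-carboxypropyl on a carbonyl carbon gives, in this assay, a 1.1-fold lower number from compound 3 to compound 4 (0.03 log units; within the scatter). For the compounds shown here, every earlier compound carried a carboxylic acid on its acyl chain or chains, whereas the entering group in compound 4 has none and is the smaller of the two, with a branched carbon chain, so this pair is the first to show that a change in the make-up of the chain, and not only in its length or number, can leave the two compounds level in this assay. No measurement offered here explains why the two compounds stand level, and the result supports no statement about the role of either group.

The compounds shown leave open whether the amine on this chain matters, since all four compounds carry one, so an acyl group without an amine, such as a plain acetyl or a longer alkyl chain, would test that directly. They also leave open whether a ring-bearing acyl group, such as benzoyl, or an amide in place of the ester would produce a step beyond the scatter.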